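Phenoxy to benzyloxy on the cyanide-bearing core

The source may report more compounds than this note shows. Statements on the series, on what has been measured and on what is new or still open speak of the compounds shown alone.

Working notes on a small set of compounds measured in a functional assay on CHO cells with metabotropic glutamate receptor 2 (Homo sapiens) as the target, read by GTPgammaS binding; on this read-out lower numbers stand for an effect already at smaller amounts and higher numbers for an effect only at larger amounts of compound. Going by the values given here, the reference point is compound 1 `N#Cc1c(-c2ccc(Oc3ccccc3)cc2)ccn2c(CC(F)(F)F)cnc12`, which in this assay gives 186 nM, the lowest of the two numbers so far. The nearest number comes from compound 3 `CCCCn1ccc(N2CCN(c3nc(C)cc(C)n3)CC2)c(C#N)c1=O`, which gives 631 nM, a higher value whose gap to compound 1 lies beyond the usual scatter. Compound 2 `CCc1cnc2c(C#N)c(N3CCN(c4ncccn4)CC3)ccn12` does not give a number in this assay but only a limit, > 3160 nM, which is the limit of > 3160 nM in this assay, at which 1 of the 3 values shown sits. Among the compounds with values here, no pair of measured compounds differs in just one place, so no single step is available to calibrate the change that follows.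

The unmeasured compound 4 `N#Cc1c(-c2ccc(OCc3ccccc3)cc2)ccn2c(CC(F)(F)F)cnc12` differs from compound 1 in one spot: benzyl in place of phenyl on an oxygen on an aromatic ring. The change inserts one more carbon between the oxygen and the aromatic ring and otherwise alters nothing in the core. Within the data shown here, with no comparable step among the measured compounds, the expectation rests only on the size of the change itself: a shift not far beyond the scatter, more likely toward a somewhat higher number than a lower one. For compound 4 the estimate in this assay is 300 nM, with a range from 80 nM to 1200 nM. Relative to compound 1 this expected step reads a 1.6-fold higher number from compound 1 to compound 4 (0.21 log units; within the scatter).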

Compound 4, half-maximal effective concentration: 158 nM
For compound 4 the middle estimate is 1.9-fold (0.28 log units) above the measured one; low and high end bracket the measured number.
By their numbers in this assay, from the lowest: compounds 4 and 1 (each within the scatter of the next); then compound 3. At a limit, above all of these: compound 2.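

In this assay, going by these compounds alone, the phenoxy to benzyloxy change reads as a 1.2-fold lower number from compound 1 to compound 4 (0.07 log units; within the scatter), and this is the first step in which only one place differs. At this position, on an oxygen on an aromatic ring, benzyl and phenyl therefore cannot be told apart by this read-out, so the added carbon in benzyl carries no visible cost or gain in this pair. No measured property among the compounds shown bears on this result, and a single pair offers no basis for explaining it.

On these data alone, it remains open whether this position accepts groups further from phenyl and benzyl, such as a longer chain like phenethyl, a small methyl, or a benzyl carrying an amine or a carboxylic acid on its ring. Within the data shown here, compounds 2 and 3 differ from compound 1 and compound 4 in more than one place, so they provide no single-place step to indicate whether the trifluoroethyl group or the aryl substituent on the shared core contributes to the values seen here.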